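Working notes: cytotoxicity of compounds 1 to 4

The source may report more compounds than this note shows. Statements on the series, on what has been measured and on what is new or still open speak of the compounds shown alone.

Measured in an ADME assay on BJ cells (Homo sapiens) for cytotoxicity, read by CellTiter-Glo and resazurin assay, with a stated time of 72 h; a higher number here means that more compound is needed for the effect, a lower number that less compound is needed:
- compound 1 `CCOC(=O)CCCCCOc1cccc(CN(C(=O)c2ccccc2)C(C)C)c1` gives only a limit, > 26000 nM.
- compound 2 `CCOC(=O)CCCCCOc1cccc(CN(C(=O)c2ccc(-c3cccc(NC(C)=O)c3)cc2)C(C)C)c1` gives only a limit, > 26000 nM.
- compound 3 `CCOC(=O)CCCCCOc1cccc(CN(C(=O)c2ccc(-c3cccnc3)cc2)C(C)C)c1` gives only a limit, > 26000 nM.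

Compound 3 therefore stands on no number at all in this assay, and the same holds for the two compounds around it, so no order among the three can be read. The steps a step that the two limits leave unreadable from compound 1 to compound 3 and a step that the two limits leave unreadable from compound 2 to compound 3 are unreadable, as is a step that the two limits leave unreadable from compound 1 to compound 2, because of the limit of > 26000 nM in this assay, at which 3 of the 3 values shown sit.

Compound 4 `CCOC(=O)CCCCCOc1cccc(CN(C(=O)c2ccc(-c3cnc(OC)nc3OC)cc2)C(C)C)c1` carries the change (2,4-dimethoxypyrimidin-5-yl in place of pyridin-3-yl on an aromatic carbon). Going by the values given here, none of the measured steps gives a readable size, so the only bearing they have is that neither the smaller change nor the larger one moved any compound off the limit. No step beyond the scatter is expected in this assay in either direction. For compound 4 the expectation is 30000 nM, within 15000 nM to 80000 nM, most likely reported once more as a limit. The step that the limit leaves unreadable from compound 3 to compound 4 implied by this estimate is expected to be nil within the scatter.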

Compound 4, half-maximal effective concentration: > 26000 nM
Compound 4: no number, only a limit; the forecaster's own chance of this, stated with the estimate: 80%; the middle value is on the limit's open side.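

No step to compound 4 from compound 1, compound 2 or compound 3 can be read in this assay, because all four compounds give only a limit and not a number: the limit of > 26000 nM in this assay, at which 4 of the 4 values shown sit.

The compounds shown leave open at what concentration any of them reaches the effect, and whether the groups on the shared core differ at all.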